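This account rests on a few compounds, and the source may have more. Where it says the series, first, only, none or still open, it means among the compounds named here.

Compound 1 `Cc1cc(NC(=O)Cn2nnc(-c3ccccc3)n2)n(C2CCCCC2)n1`: 92%; compound 2 `Cc1cc(NC(=O)Cn2nnc(-c3ccccc3)n2)n(C2CC2)n1`: > 78%; compound 3 `Cc1cc(NC(=O)Cn2nnc(-c3ccccc3)n2)n(C2CCS(=O)(=O)CC2)n1`: > 25%.

All three were measured in an assay on HEK293 cells for activation of Kir3.1/Kir3.2 (Homo sapiens), read by thallium flux; a lower number here means a smaller maximal response, a higher number a larger maximal response. For compound 2 the value shown is a limit of the assay and not a number. For compound 3 the value shown is likewise a limit. Among the measured compounds shown here, compound 1 therefore gives the only plain number among the three. Compound 4 `CC1CC1c1cc(NC(=O)Cn2nnc(-c3ccccc3)n2)n(C2CCCCC2)n1` differs from compound 1 by 2-methylcyclopropyl in place of methyl on an aromatic carbon. For the measured compounds named here, none of the measured steps touch this place: the steps a step that the limit leaves unreadable from compound 1 to compound 2, a step that the limit leaves unreadable from compound 1 to compound 3 and a step that the two limits leave unreadable from compound 2 to compound 3 all alter the group on the aromatic nitrogen, and their sizes cannot be read. Going by the values given here, no measured step bears on the change to compound 4, so a step in this assay of no more than the usual scatter is expected, a number 7 percentage points lower from compound 1 to compound 4 (within the scatter). Compound 4 is expected to give 85%, between 60% and 100%.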

Compound 4, largest response reached (Emax), in percent of the reference or control that the assay uses: 78%
Compound 4: the middle estimate sits 7 percentage points above what was measured; the range from low to high includes it.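

Among the compounds shown here, the earlier compounds differ only in the group on the aromatic nitrogen, and those steps cannot be read, so the first readable step in this assay comes from this other position: a number 14 percentage points lower from compound 1 to compound 4 (beyond the scatter). Replacing methyl with 2-methylcyclopropyl on this aromatic carbon therefore changes the response measurably, though only modestly, and a sizeable response remains. Nothing shown here accounts for this drop. From the compounds shown here alone, whether a smaller carbon group, an amine or a carboxylic acid at this position would give a higher or lower response remains open.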